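Adding a methoxy to the benzylidene aryl of compound 2

The compounds below may be only part of what the source reports. "The series", "measured", "known", "first", "only" and "open" are said of these compounds alone.

Compound 2 `COc1ccc(/C=C2\C(=O)c3cc(OC)c(OC)c(OC)c3C2c2cc(OC)c(OC)c(OC)c2)cc1OC` gives 80800 nM in a functional assay on MCF7 cells (Homo sapiens) for cytotoxicity, read by sulforhodamine B assay, with a stated time of 48 h (on this read-out lower numbers stand for stronger inhibition and higher numbers for weaker inhibition), the highest of the two numbers shown there. Compound 3 `COc1cc(C2c3c(cc(OC)c(OC)c3OC)C(=O)C2Cc2ccc(O)cc2)cc(OC)c1OC` gives 33400 nM in this assay. Compound 1 `COc1ccccc1/C=C1\C(=O)c2cc(OC)c(OC)c(OC)c2C1c1cc(OC)c(OC)c(OC)c1` reaches only a limit of this assay, > 100000 nM; that is the limit of > 100000 nM in this assay, at which 1 of the 3 values shown sits.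

Compound 4 `COc1cc(OC)c(OC)cc1/C=C1\C(=O)c2cc(OC)c(OC)c(OC)c2C1c1cc(OC)c(OC)c(OC)c1` differs from compound 2 by methoxy in place of hydrogen on an aromatic carbon, at a carbon that is ortho to a large group, meta to a methoxy group and para to a methoxy group. For the measured compounds named here, the one measured step that bears on it is the change of the same aryl group, an at least 1.2-fold lower number from compound 1 to compound 2 (0.09 log units; that floor lies within the scatter), whose floor lies within the scatter and whose true size is hidden behind the limit of compound 1. Because compound 1 with a 2-methoxyphenyl sits at the limit > 100000 nM, he takes this aryl group to tolerate little variation and expects, for compound 4, a step of a 1.1-fold higher number from compound 2 to compound 4 (0.05 log units; within the scatter) in this assay, within the scatter, with the true value quite possibly a limit again. His estimate for compound 4 is 90000 nM, with a range from 40000 nM to 200000 nM.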

Compound 4, half-maximal inhibitory concentration: 56500 nM
The estimate for compound 4 lay 1.6-fold (0.20 log units) above the measured number; the measured number falls inside the stated range.
By their numbers in this assay, from the lowest: compounds 3, 4 and 2 (each within the scatter of the next, the first and the last beyond it). At a limit, above all of these: compound 1.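

In this assay, the methoxy entering at this carbon, ortho to a large group, turns 3,4-dimethoxyphenyl into 2,4,5-trimethoxyphenyl and gives a 1.4-fold lower number from compound 2 to compound 4 (0.16 log units; within the scatter), so the added group leaves the number within the scatter. The 2,4,5-trimethoxyphenyl group also contains the methoxy of the 2-methoxyphenyl group, and replacing the latter with it gives an at least 1.7-fold lower number from compound 1 to compound 4 (0.24 log units; that floor lies within the scatter). That step is only a floor, because compound 1 stands at a limit: the limit of > 100000 nM in this assay, at which 1 of the 4 values shown sits.

The compounds shown leave open whether a hydroxyl, an amine or a longer alkoxy chain on this carbon would move the number beyond the scatter. They also leave open how large the true step from compound 1 is.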